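Adding a Second Methoxy Group to a Urea Series

A few compounds are considered here, and "the series" means these few. Any claim that something is new, unique, unknown or untested is made for them only; others in the source may bear on it.

The compounds here share a core in which a urea links a bicyclic amine bearing a pyridylmethyl arm to an aromatic ring. Compound 1 `O=C(Nc1cccc(Br)c1)N[C@@H]1C2CCN(CC2)[C@@H]1Cc1cccnc1` carries a 3-bromophenyl ring on the urea. In an assay on a protein complex for binding affinity to Neuronal acetylcholine receptor; alpha4/beta2 (Homo sapiens) (on this read-out higher numbers stand for weaker inhibition and lower numbers for stronger inhibition), compound 1 reaches only the limit of the assay, > 10000 nM, so no number is known for it. Compound 2 `COc1ccccc1NC(=O)N[C@@H]1C2CCN(CC2)[C@@H]1Cc1cccnc1` replaces that ring with a 2-methoxyphenyl group. In this assay compound 2 likewise stops at the limit, > 10000 nM. Going by the values given here, the one measured step, a step that the two limits leave unreadable from compound 1 to compound 2, therefore cannot be read, since both values sit at the limit (the limit of > 10000 nM in this assay, at which 2 of the 2 values shown sit).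

Compound 3 `COc1ccc(NC(=O)N[C@@H]2C3CCN(CC3)[C@@H]2Cc2cccnc2)c(OC)c1` is the next variation: methoxy in place of hydrogen on an aromatic carbon. Among the compounds with values here, no measured step shows what this change does, and the only comparison available, between compound 1 and compound 2, gives no readable size. Compound 3 is therefore expected to behave much like compound 2, with a step that the limit leaves unreadable from compound 2 to compound 3 in this assay, most probably again reported only as a limit. The estimated value for compound 3 in this assay is 20000 nM, within a range from 5000 nM to 100000 nM.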

Compound 3, inhibition constant: > 10000 nM
Compound 3: only a limit was reported (the forecaster's own chance of this, stated with the estimate: 80%); the middle value lies beyond the limit too.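

In this assay compound 3 gives only a limit, > 10000 nM, so no size can be read for its step from compound 2, because both compounds stop at a limit: the limit of > 10000 nM in this assay, at which 3 of the 3 values shown sit.

The compounds shown leave open what number lies behind each limit, and so whether the second methoxy group changes the binding affinity at all.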